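Aryl hydrazone variation on a shared core

This account rests on a few compounds, and the source may have more. Where it says the series, first, only, none or still open, it means among the compounds named here.

Measured compounds in a functional assay on NCI-H460 cells (Homo sapiens) for cytotoxicity, read by MTT assay, with a stated time of 72 h; a lower number here means a stronger inhibitor, a higher number a weaker inhibitor:
compound 1 `COc1ccc(OC)c(/C=N/NC(=O)Nc2ccc(Oc3ccnc(-c4nncn4CCN(C)C)c3)c(F)c2)c1` gives 2930 nM
compound 2 `CN(C)CCn1cnnc1-c1cc(Oc2ccc(NC(=O)N/N=C/c3ccc(O)c(Br)c3)cc2F)ccn1` gives 430 nM
compound 3 `CN(C)CCn1cnnc1-c1cc(Oc2ccc(NC(=O)N/N=C/c3ccccc3)cc2F)ccn1` gives 1780 nM

Compound 3 stands second highest of the three numbers in this assay; compound 1 is nearest, and compound 2 furthest. Of the steps that end at compound 3, a 1.6-fold lower number from compound 1 to compound 3 (0.22 log units; within the scatter) stays within the scatter, while a 4.1-fold higher number from compound 2 to compound 3 (0.62 log units; beyond the scatter) is a modest step beyond it. Among the measured compounds shown here, the only change so far that moved the number beyond the scatter is a 6.8-fold lower number from compound 1 to compound 2 (0.83 log units; beyond the scatter).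

Compound 4 `CN(C)CCn1cnnc1-c1cc(Oc2ccc(NC(=O)N/N=C/c3ccc(F)cc3F)cc2F)ccn1` is not yet measured. It differs from compound 3 in one place: 2,4-difluorophenyl in place of phenyl on a carbon with a double bond to nitrogen. For the measured compounds named here, no measured step introduces fluorine on this ring, so the bearing of the earlier steps is indirect. The step that swapped away a halogen-bearing ring, a 4.1-fold higher number from compound 2 to compound 3 (0.62 log units; beyond the scatter), is the closest analogue, but that ring also carried a hydroxy group; the step of a 1.6-fold lower number from compound 1 to compound 3 (0.22 log units; within the scatter) shows that a substituted ring and a bare phenyl can give numbers within the scatter of each other. For compound 4 the expected step is therefore small, a 1.4-fold lower number from compound 3 to compound 4 (0.14 log units; within the scatter), and may not clear the scatter. Compound 4 is estimated at 1300 nM, with a range from 500 nM to 3500 nM.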

Compound 4, half-maximal inhibitory concentration: 1930 nM
Beside the measured number, compound 4's estimate is 1.5-fold (0.17 log units) below it, and the stated range covers the measured number.
By their numbers in this assay, from the lowest: compound 2; then compounds 3, 4 and 1 (each within the scatter of the next).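

In this assay, adding the two fluorines changes little: a 1.1-fold higher number from compound 3 to compound 4 (0.04 log units; within the scatter), so this assay does not separate 2,4-difluorophenyl from phenyl on the carbon with a double bond to nitrogen. The comparison with the dimethoxy ring gives the same reading, a 1.5-fold lower number from compound 1 to compound 4 (0.18 log units; within the scatter), and places phenyl, 2,4-difluorophenyl and 2,5-dimethoxyphenyl together within the scatter, while a 4.5-fold higher number from compound 2 to compound 4 (0.65 log units; beyond the scatter) shows a modest step beyond it and leaves the 3-bromo-4-hydroxyphenyl ring of compound 2 as the only one set apart among these four compounds. The compounds come with no separate measurement that bears on this grouping, so the numbers describe it without accounting for it.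

Compound 2 carries the bromine and the hydroxy group on one ring, so these compounds cannot show whether a ring with only the hydroxy group or only the bromine would keep the lower number. On these data alone, how a phenyl ring bearing an amine or a carboxylic acid would read at this position also remains open.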